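A few compounds are considered here, and "the series" means these few. Any claim that something is new, unique, unknown or untested is made for them only; others in the source may bear on it.

Of the compounds shown here, two have been measured in an assay on VSM-A10 cells for antagonist activity at Endothelin-1 receptor (Rattus norvegicus); on this read-out lower numbers stand for stronger inhibition and higher numbers for weaker inhibition. Compound 1 `CCCCCNc1cccc2c(S(=O)(=O)Nc3onc(C)c3C)cccc12` gives 80 nM in this assay, the higher of the two numbers. Compound 2 `Cc1onc(NS(=O)(=O)c2cccc3c(N(C)C)cccc23)c1C` gives 60 nM in this assay, and the gap to compound 1 lies within the usual scatter, so the two stand together rather than in any order. Compound 3 `CNc1cccc2c(S(=O)(=O)Nc3onc(C)c3C)cccc12` remains to be measured in this assay; it differs from compound 1 by hydrogen in place of butyl on a saturated chain carbon bound to a nitrogen on an aromatic ring, the same difference read one bond further out being pentylamino to methylamino. Going by the values given here, no measured pair shows a step of this kind, and the two values known say only that short and long amine substituents on the shared core both land in the same region. The step is therefore expected to be a 1.5-fold higher number from compound 1 to compound 3 (0.18 log units; within the scatter), a modest move toward a weaker number, not clearly beyond the scatter. For compound 3 the estimate in this assay is 120 nM, with a range from 40 nM to 400 nM.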

Compound 3, half-maximal inhibitory concentration: 130 nM
The estimate for compound 3 lay 1.1-fold (0.03 log units) below the measured number; low and high end bracket the measured number.
By their numbers in this assay, from the lowest: compounds 2, 1 and 3 (each within the scatter of the next, the first and the last beyond it).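

In this assay hydrogen in place of butyl on a saturated chain carbon bound to a nitrogen on an aromatic ring, the same difference as pentylamino to methylamino, gives a 1.6-fold higher number from compound 1 to compound 3 (0.21 log units; within the scatter). Going by these compounds alone, this is the first single-place step read at this position, and removing the butyl, with its 4 carbon atoms, leaves no difference that can be told from the scatter. No measurement on hand gives a reason for this result.

Still open, as far as these compounds go, is whether a plain primary amine, a chain longer than pentyl, or a chain ending in a carboxylic acid would separate from these values. From the compounds shown here alone, a phenyl or cyclohexyl ring on the same nitrogen is equally open, so the limits of what this position accepts remain undefined.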